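The source may hold more compounds than are shown below. What is called first, only, known or untested is meant among the compounds shown, and "the series" means these compounds.

Among the compounds with values here, compound 1 `COc1ccc(/C=C/C(=O)c2c(OC)cc(O)c(CC=C(C)C)c2O)cc1OC` is the first reference point. In a functional assay on HeLa cells (Homo sapiens) for inhibition, read by MTT assay, with a stated time of 72 h (a lower number here means a stronger inhibitor, a higher number a weaker inhibitor), compound 1 gives 27700 nM. Compound 2 `COc1cc(/C=C/C(=O)c2c(OC)cc(O)c(CC=C(C)C)c2O)cc(OC)c1OC` carries one more group, (methoxy in place of hydrogen on an aromatic carbon). In this assay compound 2 gives only a limit of the assay, > 50000 nM, which is the limit of > 50000 nM in this assay, at which 1 of the 3 values shown sits. The step of an at least 1.8-fold higher number from compound 1 to compound 2 (0.25 log units; that floor lies within the scatter) can therefore be placed no more precisely than that floor. Compound 3 `COc1cc(O)cc(O)c1C(=O)/C=C/c1ccc(O)cc1` is built on a different core; the difference between the two cores is not broken down here. In this assay compound 3 gives 48100 nM, a number that lies within the scatter of the number for compound 1, so no order can be read between them. Compound 4 `COc1cc(/C=C/C(=O)c2c(O)cc(O)cc2OC)ccc1O` has not yet been measured; it differs from compound 3 by methoxy in place of hydrogen on an aromatic carbon. Within the data shown here, this is the same kind of change as the one made between compound 1 and compound 2, but not the same change: in compound 4 the entering methoxy sits ortho to a hydroxy group and meta to a large group, whereas in compound 2 it sits ortho to a methoxy group, meta to a large group and meta to a methoxy group. Among the measured compounds shown here, the only measured example of this kind of change is the step of an at least 1.8-fold higher number from compound 1 to compound 2 (0.25 log units; that floor lies within the scatter), which points toward a higher number but is known only as a floor. For compound 4 a step of about a 1.2-fold higher number from compound 3 to compound 4 (0.10 log units; within the scatter) in this assay is expected, resting on that measured step and on the starting number of compound 3, which already stands close to the limit. The estimate for compound 4 is 60000 nM, with a likely range from 30000 nM to 120000 nM, and it is expected that the assay may report only a limit.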

Compound 4, half-maximal inhibitory concentration: > 50000 nM
Compound 4: only a limit was reported (the forecaster's own chance of this, stated with the estimate: 55%); the middle value does not contradict the limit.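

In this assay compound 4 gives only a limit of the assay, > 50000 nM. The new step can therefore be read only as a floor, an at least 1.0-fold higher number from compound 3 to compound 4 (0.01 log units; that floor lies within the scatter), and that floor does not establish that methoxy in place of hydrogen on this aromatic carbon changes the number on the core of compound 3. Both examples of the change are thus known only as floors, and the entering methoxy stands ortho to a hydroxy group in compound 4, so the series neither shows that the change carries over from one core to the other with the same size nor shows that its size differs: the same change on two cores in this assay, an at least 1.8-fold higher number (0.25 log units; that floor lies within the scatter) from compound 1 to compound 2 and an at least 1.0-fold higher number (0.01 log units; that floor lies within the scatter) from compound 3 to compound 4; the limit leaves it open whether they differ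

The compounds shown leave open how far the true numbers lie past the limit, and with them the size of the change on either core: the limit of > 50000 nM in this assay, at which 2 of the 4 values shown sit. They also leave open whether an amine, a carboxylic acid or a longer chain such as ethoxy, placed on the same aromatic carbon in place of methoxy, would give a number on either core that could be read as a value rather than as a limit.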